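The source may hold more compounds than are shown below. What is called first, only, known or untested is meant among the compounds shown, and "the series" means these compounds.

Compound 1 `COc1ccc(Cc2nnc(NC(=O)/C(C#N)=C/c3ccccc3OS(=O)(=O)c3ccc([N+](=O)[O-])cc3)s2)cc1` was tested in a functional assay on HL-60 cells (Homo sapiens) for inhibition, read by CCK-8 assay, with a stated time of 48 h, tested at 20 uM (on this read-out higher numbers stand for more inhibition of growth at the one concentration tested and lower numbers for less inhibition of growth), where compound 1 gives 51%. Compound 2 `COc1ccc(Cc2nnc(NC(=O)/C(C#N)=C/c3ccccc3OS(=O)(=O)c3ccccc3[N+](=O)[O-])s2)cc1` carries the change (2-nitrophenyl in place of 4-nitrophenyl on a sulfonyl sulfur), and in this assay compound 2 gives 25%, so that a number 26 percentage points lower from compound 1 to compound 2 (beyond the scatter). Compound 3 `N#C/C(=C\c1ccccc1OS(=O)(=O)c1ccc([N+](=O)[O-])cc1)C(=O)Nc1nnc(Cc2ccc(F)cc2)s1` differs from compound 1 by fluoro in place of methoxy on an aromatic carbon; in this assay compound 3 gives 18%, and a number 33 percentage points lower from compound 1 to compound 3 (beyond the scatter). Compound 4 `N#C/C(=C\c1ccccc1OS(=O)(=O)c1ccccc1[N+](=O)[O-])C(=O)Nc1nnc(Cc2ccc(F)cc2)s1` has not yet been measured. It is built from compound 3 by the same change that turned compound 1 into compound 2, (2-nitrophenyl in place of 4-nitrophenyl on a sulfonyl sulfur), with the same surroundings at the place of change. Resting on the earlier step, a number 26 percentage points lower from compound 1 to compound 2 (beyond the scatter), and on the low starting value of compound 3, 18%, the step expected here is a number 10 percentage points lower from compound 3 to compound 4 (within the scatter). For compound 4 the estimate in this assay is 8%, expected between -5% and 22%.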

Compound 4, percent growth inhibition at one concentration: 35%
Compound 4: the middle estimate sits 27 percentage points below what was measured, outside the stated range (above it).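

In this assay, the change from 4-nitrophenyl to 2-nitrophenyl on the sulfonyl sulfur did not carry over from one core to the other, giving a number 17 percentage points higher from compound 3 to compound 4 (beyond the scatter), opposite in direction to the earlier step: the same change on two cores in this assay, a number 26 percentage points lower (beyond the scatter) from compound 1 to compound 2 and a number 17 percentage points higher (beyond the scatter) from compound 3 to compound 4, 43 percentage points apart, beyond the scatter of two such steps. Read the other way, fluoro in place of methoxy gives a number 10 percentage points higher from compound 2 to compound 4 (within the scatter), and this too depends on the surroundings: the same change on two cores in this assay, a number 33 percentage points lower (beyond the scatter) from compound 1 to compound 3 and a number 10 percentage points higher (within the scatter) from compound 2 to compound 4, 43 percentage points apart, beyond the scatter of two such steps. For the compounds shown here, this shows that the two changes do not act independently in these compounds, but with only one pair of cores it gives no reason for the reversal and no general rule for either nitrophenyl.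

On these data alone, it remains open whether a chloro or a methyl in place of the fluoro or methoxy would follow the fluoro or the methoxy compounds. The same applies to an amine in place of the nitro group.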